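Thiophene for furan on the shared core

The source may report more compounds than this note shows. Statements on the series, on what has been measured and on what is new or still open speak of the compounds shown alone.

Of the compounds shown here, two have been measured in an assay on membranes from CHO cells for displacement of a labelled ligand from adenosine receptor A1 (Homo sapiens), read by scintillation counting, with a stated time of 60 min, tested at 1 uM; on this read-out lower numbers stand for less inhibition and higher numbers for more inhibition at the one concentration tested (going by the name of the read-out). Compound 1 `CC1=C(C(=O)OCC(C)C)C(c2cccs2)NC(=O)N1` gives 25% in this assay. Compound 2 `CCNC(=O)C1=C(C)NC(=O)NC1c1ccoc1` gives 1% in this assay, the lowest of the two numbers; the nearest is compound 1, which stands higher by an amount beyond the usual scatter. Compound 3 `CCNC(=O)C1=C(C)NC(=O)NC1c1cccs1` has not yet been measured in this assay. It differs from compound 2 in one place: thiophen-2-yl in place of furan-3-yl on a saturated ring carbon. Among the measured compounds shown here, no step between measured compounds that differ in a single place is available, so the size of this change has to be judged from the two numbers alone. Compound 1 carries a thiophen-2-yl group on a saturated ring carbon and gives 25%, while compound 2 with furan-3-yl gives 1%; the two also differ elsewhere, so only a loose guide results. An upward step of modest size is expected in this assay, as a number 9 percentage points higher from compound 2 to compound 3 (within the scatter), likely within or just beyond the scatter. For compound 3 the estimate in this assay is 10%, within a range from 0% to 28%.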

Compound 3, a percentage reported as inhibition, at one concentration (the size of the read-out at that concentration, not a potency): 1%
Compound 3: middle estimate off by 9 percentage points, on the high side; low and high end bracket the measured number.
By their numbers in this assay, from the lowest: compounds 2 and 3 (each within the scatter of the next); then compound 1.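

In this assay, thiophen-2-yl in place of furan-3-yl on a saturated ring carbon, with the ethylcarbamoyl group kept, gives no change at the digits printed from compound 2 to compound 3 (within the scatter), so this read-out does not separate the two rings in this setting. Among the compounds shown here, with thiophen-2-yl held constant, ethylamino in place of isobutoxy on a carbonyl carbon gives a number 24 percentage points lower from compound 1 to compound 3 (beyond the scatter), the first single-place comparison at that carbonyl, and there the change does separate the two compounds. No supporting data bear on the reason for either step.

Going by these compounds, compound 2 and compound 3 both stand at the low end of this assay, so it remains open whether the same ring change would also leave the number in place with isobutoxy on the carbonyl carbon, where compound 1 gives 25%. Also open, on these data alone, is how a phenyl ring on the saturated ring carbon, or a longer chain such as butylamino or a free carboxylic acid at the carbonyl, would read in this assay series.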